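The source may report more compounds than this note shows. Statements on the series, on what has been measured and on what is new or still open speak of the compounds shown alone.

In a functional assay on PC-3 cells (Homo sapiens) for antiproliferative activity, read by MTT assay, with a stated time of 72 h (a lower number here means a stronger inhibitor, a higher number a weaker inhibitor), compound 1 `O=S(=O)(c1ccc(-c2cnc(C3CC3)o2)cc1)N1CCCOc2ccccc21` gives 27 nM. Two close relatives carry one extra halogen atom on the aromatic ring of the core: compound 2 `O=S(=O)(c1ccc(-c2cnc(C3CC3)o2)cc1)N1CCCOc2ccc(Cl)cc21` gives 18 nM and compound 3 `O=S(=O)(c1ccc(-c2cnc(C3CC3)o2)cc1)N1CCCOc2ccc(F)cc21` gives 18 nM. Compound 1 therefore stands within the usual scatter of both. Compound 4 `COc1ccc2c(c1)OCCCN2S(=O)(=O)c1ccc(-c2cnc(C3CC3)o2)cc1` has not yet been measured. It differs from compound 1 by methoxy in place of hydrogen on an aromatic carbon.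

Within the data shown here, two measured steps bear on this change: chloro gives a 1.5-fold lower number from compound 1 to compound 2 (0.18 log units; within the scatter), and fluoro gives a 1.5-fold lower number from compound 1 to compound 3 (0.18 log units; within the scatter). Both are small, and swapping one halogen for the other gives no change at the digits printed from compound 2 to compound 3 (within the scatter). These steps are only a partial guide, since neither tests methoxy and both halogens sit on a different carbon of that ring. No step beyond the scatter is therefore expected in this assay, in either direction, though the uncertainty is wider than for a halogen. The expected change is a 1.2-fold lower number from compound 1 to compound 4 (0.09 log units; within the scatter). The estimate for compound 4 is 22 nM, with an expected range from 9 nM to 55 nM.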

Compound 4, half-maximal inhibitory concentration: 271 nM
Estimate against measurement, compound 4: 12-fold (1.09 log units) below; the measured number lies above the stated range.
By their numbers in this assay, from the lowest: compounds 2, 3 and 1 (each within the scatter of the next); then compound 4.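

In this assay, among these compounds, methoxy on this aromatic carbon, meta to a fused ring and para to a fused ring, gives a 10-fold higher number from compound 1 to compound 4 (1.00 log units; beyond the scatter) and is the only step in this set beyond the scatter. The chloro and fluoro steps, on a different carbon of the same ring, stayed within the scatter, so they gave no sign that a single group on this ring could shift the number this far. No measurement at hand accounts for this step.

The compounds shown do not separate the effect of the methoxy group from the effect of its carbon, since no single group appears on both carbons. Chloro or fluoro on this carbon, methoxy on the carbon bearing the halogens, and a methyl, hydroxy or ethoxy group here would help settle that.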